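This account rests on a few compounds, and the source may have more. Where it says the series, first, only, none or still open, it means among the compounds named here.

Working notes on a short amide series. Compound 1, `COc1ccc(F)c(CNC(C)=O)c1`, is the anchor: in an assay on isolated protein for agonist activity at melatonin receptor type 1C (Xenopus laevis), read by spectrophotometry (on this read-out higher numbers stand for larger maximal responses and lower numbers for smaller maximal responses), compound 1 gives 100%. Compound 2, `CCC(=O)NCc1cc(OC)ccc1F`, carries methyl in place of hydrogen on a saturated chain carbon bound to a carbonyl carbon; in this assay compound 2 gives 69%, the step being a number 31 percentage points lower from compound 1 to compound 2 (beyond the scatter). Compound 3, `CCC(=O)NCCCc1ccc(OC)c(F)c1`, rests on another core; how the core of compound 3 differs from the core of compound 1 is not broken down here. In this assay compound 3 gives 78%, a value close to that of compound 2. Compound 4, `CCCC(=O)NCCCc1ccc(OC)c(F)c1`, is unmeasured; from compound 3 it differs by methyl in place of hydrogen on a saturated chain carbon, two bonds along the chain from a carbonyl carbon. For the measured compounds named here, this is the same kind of change as the one in compound 2, not the same: there the methyl entered on a saturated chain carbon bound to a carbonyl carbon, here on a saturated chain carbon, two bonds along the chain from a carbonyl carbon, and on a different core. Going by the values given here, the sole precedent, a number 31 percentage points lower from compound 1 to compound 2 (beyond the scatter), points downward, but its transfer to a more distant place and another core is uncertain, so a smaller drop is expected: the step from compound 3 to compound 4 is estimated at a number 18 percentage points lower from compound 3 to compound 4 (beyond the scatter). Compound 4 is thus expected to give about 60% in this assay, within a plausible range from 35% to 85%.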

Compound 4, largest response reached (reported as efficacy), in percent of the reference or control that the assay uses: 73%
Beside the measured number, compound 4's estimate is 13 percentage points below it; the measured number falls inside the stated range.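

In this assay, the methyl step does not carry over from one core to the other at a constant size: the same change on two cores in this assay, a number 31 percentage points lower (beyond the scatter) from compound 1 to compound 2 and a number 5 percentage points lower (within the scatter) from compound 3 to compound 4, 26 percentage points apart, beyond the scatter of two such steps
On the core of compound 3, the step is a number 5 percentage points lower from compound 3 to compound 4 (within the scatter), so no effect of the added methyl is resolved there. Core and place remain unseparated: the methyl enters on a saturated chain carbon bound to a carbonyl carbon in one step and on a saturated chain carbon, two bonds along the chain from a carbonyl carbon, in the other, with a single pair for each core.

Open, from the compounds shown here alone, is how the same change at the more distant place reads on the core of compound 1. Also open, going by these compounds, is whether a longer chain or a terminal amine on the acyl side would keep the response of compound 4.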